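The source may report more compounds than this note shows. Statements on the series, on what has been measured and on what is new or still open speak of the compounds shown alone.

Measured compounds in an ADME assay on THP-1 cells (Homo sapiens) for cytotoxicity, read by MTT assay; on this read-out lower numbers stand for higher toxicity in this test and higher numbers for lower toxicity in this test:
compound 1 `Cc1nc(-c2cccnc2)sc1-c1nnc(-c2ccncc2)o1` — > 100 ug/mL
compound 2 `Cc1nc(-c2cccnc2)sc1-c1nnc(-c2ccc(Br)cc2)o1` — > 100 ug/mL
compound 3 `Cc1nc(-c2cccnc2)sc1-c1nnc(-c2cccnc2)o1` — > 100 ug/mL

Each of these values is a limit of the assay, not a number. Compound 3 thus stands at the limit of > 100 ug/mL in this assay, at which 3 of the 3 values shown sit, and the two other values shown sit at that same limit. The steps from compound 1 to compound 3, a step that the two limits leave unreadable from compound 1 to compound 3, and from compound 2 to compound 3, a step that the two limits leave unreadable from compound 2 to compound 3, cannot be sized; both ends of each are limits.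

Next is compound 4 `Cc1ccc(-c2nnc(-c3sc(-c4cccnc4)nc3C)o2)cc1`. It differs from compound 3 by 4-methylphenyl in place of pyridin-3-yl on an aromatic carbon. The step from compound 2 to compound 3 bears most on this change, as it also exchanges a six-membered carbon-only ring against pyridin-3-yl, here taken in the reverse direction; its size is unreadable. The step from compound 1 to compound 2 likewise gives no readable size, a step that the two limits leave unreadable from compound 1 to compound 2. With all three measured compounds at the limit, no step beyond the scatter is expected in this assay, and the most likely outcome is again a limit. The expected step from compound 3 to compound 4 is a step that the limit leaves unreadable from compound 3 to compound 4. Compound 4 is estimated at 150 ug/mL, between 60 ug/mL and 400 ug/mL.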

Compound 4, half-maximal cytotoxic concentration: > 100 ug/mL
Compound 4: no number, only a limit; the forecaster's own chance of this, stated with the estimate: 85%; the middle value lies beyond the limit too.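

In this assay compound 4 gives only a limit, so no step from compound 1, compound 2 or compound 3 to compound 4 can be read: the limit of > 100 ug/mL in this assay, at which 4 of the 4 values shown sit.

The compounds shown leave open how these four differ in cytotoxicity, and whether any change on the shared core gives a value that is not a limit.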